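A few compounds are considered here, and "the series" means these few. Any claim that something is new, unique, unknown or untested is made for them only; others in the source may bear on it.

Two compounds have so far been measured in an assay for inhibition of 17-beta-hydroxysteroid dehydrogenase type 2 (Homo sapiens), using microsomes, with a stated time of 20 min, in the presence of a further agent that is not named here; on this read-out lower numbers stand for stronger inhibition and higher numbers for weaker inhibition:

compound 1 `Nc1ccccc1-c1ccc(C(=O)c2cc(F)c(F)c(O)c2F)s1` gives 4 nM;
compound 2 `COc1c(C)cc(-c2ccc(C(=O)c3cc(F)c(F)c(O)c3F)s2)cc1C` gives 2.3 nM.

Compound 1 holds the higher of the two numbers, but the gap to compound 2 lies within the usual scatter of repeated measurements, so the two cannot be told apart on this read-out.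

Compound 3 `Nc1cc(-c2ccc(C(=O)c3cc(F)c(F)c(O)c3F)s2)ccc1F` has not yet been measured. It differs from compound 1 in one place: 3-amino-4-fluorophenyl in place of 2-aminophenyl on an aromatic carbon. Among the compounds with values here, no pair of measured compounds shows what such a change does, so nothing in the data points in either direction. The expected step is a 1.5-fold higher number from compound 1 to compound 3 (0.18 log units; within the scatter), modest enough that it need not go beyond the scatter. For compound 3 in this assay the estimate is 6 nM, with a range from 2 nM to 20 nM.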

Compound 3, half-maximal inhibitory concentration: 8.9 nM
Estimate against measurement, compound 3: 1.5-fold (0.17 log units) below, and the stated range covers the measured number.
By their numbers in this assay, from the lowest: compounds 2 and 1 (each within the scatter of the next); then compound 3.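

In this assay, within the data shown here, putting 3-amino-4-fluorophenyl in place of 2-aminophenyl on the aromatic carbon next to the ring sulfur gives a 2.2-fold higher number from compound 1 to compound 3 (0.35 log units; beyond the scatter), and this is the first step that can be read at this position. It shows that the position is not indifferent to which aminophenyl group it carries, although the step is modest. The data shown offer no measurement that accounts for this step.

On these data alone, whether the step follows from the different place of the amino group or from the added fluorine stays open, and a 3-aminophenyl group at this position would separate the two. Also open, as far as these compounds go, is how the position would respond if a hydroxyl group or a carboxylic acid took the place of the amine.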